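Three Rhodanine Benzoic Acids at the Limit, One Awaited

The compounds below may be only part of what the source reports. "The series", "measured", "known", "first", "only" and "open" are said of these compounds alone.

Compound 2 `Cc1cccc(N2C(=O)/C(=C/c3ccc(OCc4ccc(C(=O)O)cc4)cc3)SC2=S)c1` was tested in an assay on isolated protein for inhibition of Apoptosis regulator Bcl-2 (Homo sapiens), read by fluorescence polarization; on this read-out higher numbers stand for weaker inhibition and lower numbers for stronger inhibition. In this assay compound 2 gave only a limit, > 10000 nM. Compound 1 `O=C(O)c1ccc(COc2cccc(/C=C3\SC(=S)N(c4ccccc4)C3=O)c2)cc1` likewise gave only a limit in this assay, > 10000 nM. Compound 3 `Cc1cccc(N2C(=O)/C(=C/c3ccc(OCC(=O)Nc4ccc(C(=O)O)cc4)cc3)SC2=S)c1` also gave only a limit in this assay, > 10000 nM. So compound 2 stands nowhere apart from its companions: all three values shown sit at the limit of > 10000 nM in this assay, at which 3 of the 3 values shown sit, and no numbered step between measured compounds exists here. Compound 4 `O=C(O)c1ccc(COc2ccc(/C=C3\SC(=S)N(Cc4ccc(F)cc4)C3=O)cc2)cc1` has not yet been measured in this assay. It differs from compound 2 in one place: 4-fluorobenzyl in place of 3-methylphenyl on an amide-type nitrogen in a ring. For the measured compounds named here, with no measured step to lean on, the expected change is none beyond the scatter, and the expected step from compound 2 to compound 4 in this assay is a step that the limit leaves unreadable from compound 2 to compound 4, most likely ending again at a limit rather than a number. The estimate for compound 4 in this assay is 15000 nM, within a range from 4000 nM to 60000 nM.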

Compound 4, inhibition constant: > 10000 nM
Compound 4: only a limit was reported (the forecaster's own chance of this, stated with the estimate: 80%); the middle value is on the limit's open side.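

For the compounds shown here, compound 2 and compound 4 both gave only limits in this assay, so no step between them can be read. The compounds shown leave open whether any group on the amide-type nitrogen in a ring, or any other change to the shared core, would give a number rather than a limit.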